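Isopropoxy Replaces Methyl on the Fused Ring of Compound 3

A few compounds are considered here, and "the series" means these few. Any claim that something is new, unique, unknown or untested is made for them only; others in the source may bear on it.

The study follows three measured analogues that share one core. Compound 1 `CC#C[C@@H](CC(=O)O)c1ccc(OC[C@H]2COc3ccc(Cl)cc3O2)cc1` reaches 86% in a functional assay on HEK293 cells for agonist activity at Free fatty acid receptor 1 (Homo sapiens), read by fluorescence and calcium flux, with a stated time of 10 min; a higher number here means a larger maximal response, a lower number a smaller maximal response. Compound 2 `CC#C[C@@H](CC(=O)O)c1ccc(OC[C@H]2COc3ccc(F)cc3O2)cc1` reaches 86% in this assay, and compound 3 `CC#C[C@@H](CC(=O)O)c1ccc(OC[C@H]2COc3ccc(C)cc3O2)cc1` reaches 78%. Compound 3 thus shows the smallest of the three numbers, but the gaps are small: a number 8 percentage points lower from compound 1 to compound 3 (within the scatter) and a number 8 percentage points lower from compound 2 to compound 3 (within the scatter), both within the scatter, and no change at the digits printed from compound 1 to compound 2 (within the scatter).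

Compound 4 `CC#C[C@@H](CC(=O)O)c1ccc(OC[C@H]2COc3ccc(OC(C)C)cc3O2)cc1` differs from compound 3 in one place: isopropoxy in place of methyl on an aromatic carbon. Within the data shown here, the three measured steps all swap small substituents at this aromatic carbon, and none moved the maximal response beyond the scatter; none, however, introduces an isopropoxy, so the new group has no direct precedent here. On that basis the step is expected to stay within the scatter, with a number 4 percentage points higher from compound 3 to compound 4 (within the scatter) as the estimated change. For compound 4 the expected maximal response in this assay is 82%, with a range of 70% to 94%.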

Compound 4, largest response reached (Emax), in percent of the reference or control that the assay uses: 90%
Estimate against measurement, compound 4: 8 percentage points below; the range from low to high includes it.
By their numbers in this assay, from the lowest: compounds 3, 1, 2 and 4 (each within the scatter of the next, the first and the last beyond it).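

At this aromatic carbon, isopropoxy gives the only step shown that passes the scatter in this assay with a number 12 percentage points higher from compound 3 to compound 4 (beyond the scatter) as its size. Set against the other two substituents, the same group gives a number 4 percentage points higher from compound 2 to compound 4 (within the scatter) and a number 4 percentage points higher from compound 1 to compound 4 (within the scatter) as its steps, so the gain is clear only against methyl, and the position carries isopropoxy, with its 4 heavy atoms, with no fall in maximal response against any of the three.

The compounds shown leave open whether methoxy, a longer ether such as butoxy, or an amine at this aromatic carbon would give a similar maximal response. Potency, as distinct from the maximal response in this assay also stays open for compound 4. Nothing available here accounts for the step from methyl to isopropoxy.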